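The compounds below may be only part of what the source reports. "The series", "measured", "known", "first", "only" and "open" are said of these compounds alone.

Compounds measured in a functional assay on the whole organism with Mus musculus as the target, in the rotarod test; on this read-out higher numbers stand for an effect only at larger amounts of compound and lower numbers for an effect already at smaller amounts:
Compound 1, `CC(C)NCC(=O)NCC(=O)N(C)c1ccc(Cl)cc1C(=O)c1ccccc1Cl`: 13 mg/kg
Compound 2, `NCC(=O)NCC(=O)Nc1ccc([N+](=O)[O-])cc1C(=O)c1ccccc1`: 24.8 mg/kg
Compound 3, `CN(C(=O)CNC(=O)CN)c1ccc([N+](=O)[O-])cc1C(=O)c1ccccc1`: 2.94 mg/kg

Among these three numbers, compound 1 gives the second highest. Its nearest neighbour is compound 2, whose number sits within the scatter of that of compound 1, so the two cannot be told apart. Compound 3 stands further off, with a number beyond the scatter below that of compound 1. Going by the values given here, the only single-point step measured so far runs an 8.4-fold lower number from compound 2 to compound 3 (0.93 log units; beyond the scatter).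

The compound still to be measured is compound 4, `CN(C(=O)CNC(=O)CN)c1ccc(Cl)cc1C(=O)c1ccccc1Cl`. It differs from compound 1 in one place: hydrogen in place of isopropyl on an amine nitrogen. Among the compounds with values here, none of the measured steps concerns this change; the step from compound 2 to compound 3 touches an amide-type nitrogen, not the amine nitrogen, and gives no guide here. What the data do offer is the number of a compound that carries the same amino group as compound 4 on a differently substituted core: compound 3 gives 2.94 mg/kg.

Compound 4 is therefore expected to give 7 mg/kg, with a range from 2.5 mg/kg to 20 mg/kg. This estimate implies a step of a 1.9-fold lower number from compound 1 to compound 4 (0.27 log units; within the scatter), judged likely to fall within or only modestly beyond the scatter.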

Compound 4, dose for half-maximal effect: 27.7 mg/kg
Beside the measured number, compound 4's estimate is 4.0-fold (0.60 log units) below it, outside the stated range (above it).
By their numbers in this assay, from the lowest: compound 3; then compounds 1, 2 and 4 (each within the scatter of the next, the first and the last beyond it).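

In this assay, going by these compounds alone, hydrogen in place of isopropyl on the amine nitrogen gives a 2.1-fold higher number from compound 1 to compound 4 (0.33 log units; beyond the scatter) and so provides the first measured change at this position, since the only earlier step concerned an amide-type nitrogen. The step is modest but beyond the scatter, and its direction shows that, on the core of compound 1, the compound carrying isopropyl acts at smaller amounts than the one with the free amino group, so the isopropyl group is at least tolerated here and the unsubstituted amine brings no gain. Nothing available explains this difference.

The compounds shown leave open whether a methyl, an ethyl or a longer chain such as n-butyl on the amine nitrogen, or a cyclopropyl ring in the same place, would follow the same direction or depart from it. They also leave open whether the same exchange of isopropyl and hydrogen would shift the number in the same direction on the core of compound 3, for which only the form with the free amino group appears here.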